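The source may report more compounds than this note shows. Statements on the series, on what has been measured and on what is new or still open speak of the compounds shown alone.

Measured compounds in a functional assay on MCF7 cells (Homo sapiens), tested at 7.5 uM; a lower number here means a stronger effect, a higher number a weaker effect of the compound at the concentration tested:
compound 1 `CCOc1cc(/C=C2\SC(=O)NC2=O)ccc1OCC1(C)CCc2c(C)c(OCC=C(C)C)c(C)c(C)c2O1` gives 54%
compound 2 `C=CCOc1c(C)c(C)c2c(c1C)CCC(C)(COc1ccc(/C=C3\SC(=O)NC3=O)cc1OCC)O2` gives 75%
compound 3 `Cc1c(C)c2c(c(C)c1OC(=O)CCC(=O)O)CCC(C)(COc1ccc(/C=C3\SC(=O)NC3=O)cc1)O2` gives 76%

Compound 1 stands lowest of the three numbers in this assay; compound 2 sits a number 21 percentage points higher from compound 1 to compound 2 (beyond the scatter), and compound 3 lies further out still. Compound 4 `COc1cc(/C=C2\SC(=O)NC2=O)ccc1OCC1(C)CCc2c(C)c(OCC=C(C)C)c(C)c(C)c2O1` is not yet measured. It differs from compound 1 by hydrogen in place of methyl on a saturated chain carbon bound to an oxygen on an aromatic ring, the same difference read one bond further out being ethoxy to methoxy. Among the measured compounds shown here, none of the measured steps alters this ethoxy: the only single step in hand, from compound 1 to compound 2, changes a different chain elsewhere on the shared core, and compound 3 differs in several places at once. For the measured compounds named here, no step therefore bears directly on the change, and no shift beyond the scatter is expected. Compound 4 is estimated at 57% (range 42% to 72%), meaning an expected step of a number 3 percentage points higher from compound 1 to compound 4 (within the scatter).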

Compound 4, a percentage reported as activity, at one concentration (the size of the read-out at that concentration, not a potency): 54%
Compound 4: the middle estimate sits 3 percentage points above what was measured, and the stated range covers the measured number.
By their numbers in this assay, from the lowest: compounds 1 and 4 (each within the scatter of the next); then compounds 2 and 3 (each within the scatter of the next).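

In this assay, among the compounds shown here, ethoxy to methoxy gives no change at the digits printed from compound 1 to compound 4 (within the scatter) and is the first change read at this place, since the earlier step altered only the other chain on the shared core. With that other chain kept as in compound 1, ethoxy and methoxy are therefore interchangeable here within the scatter. Nothing available gives a reason for this result.

Still open, as far as these compounds go, is whether a longer chain such as propoxy, or a hydroxyl group, would keep the number at this place. Also open, from the compounds shown here alone, is whether methoxy would read the same alongside the shorter chain of compound 2.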